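Cyanoguanidine dihydropyrimidine series: aryl swap at the saturated ring carbon

A few compounds are considered here, and "the series" means these few. Any claim that something is new, unique, unknown or untested is made for them only; others in the source may bear on it.

Measured so far:
Compound 1 `CC1=C(C(=O)OC(C)C)C(c2ccccc2)N/C(=N/C#N)N1`: 20%
Compound 2 `CCOC(=O)C1=C(C)N/C(=N\C#N)NC1c1cccs1`: 26%
Compound 3 `CC1=C(C(=O)OC(C)C)C(c2cccs2)N/C(=N/C#N)N1`: 31%

All three were run in an assay on cells for displacement of a labelled ligand from adenosine receptor A1 (Homo sapiens), with a stated time of 60 min, tested at 1 uM; a lower number here means less inhibition, a higher number more inhibition at the concentration tested (going by the name of the read-out). Compound 2 sits second highest of the three numbers; its nearest neighbour is compound 3, and the two differ only by methyl in place of hydrogen on a saturated chain carbon bound to an oxygen next to a carbonyl group and a saturated chain carbon, a step of a number 5 percentage points higher from compound 2 to compound 3 (within the scatter). Compound 1 lies furthest from compound 2, but still within the scatter of it.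

Compound 4 `CCOC(=O)C1=C(C)N/C(=N\C#N)NC1c1ccccc1` is not yet measured. Relative to compound 2 the change is phenyl in place of thiophen-2-yl on a saturated ring carbon. For the measured compounds named here, the only measured step that bears on this is the reverse swap on the isopropyl ester pair, a number 11 percentage points higher from compound 1 to compound 3 (beyond the scatter), a modest shift beyond the scatter. Running that step backwards from compound 2, a decrease of about the same size is expected, so compound 4 is estimated at 15%, between 4% and 28%, which would mean an expected step of a number 11 percentage points lower from compound 2 to compound 4 (beyond the scatter) in this assay.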

Compound 4, a percentage reported as inhibition, at one concentration (the size of the read-out at that concentration, not a potency): 18%
Compound 4: middle estimate off by 3 percentage points, on the low side, within the range that was stated.
By their numbers in this assay, from the lowest: compounds 4, 1, 2 and 3 (each within the scatter of the next, the first and the last beyond it).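

On the core with the ethoxycarbonyl group, phenyl in place of thiophen-2-yl on the saturated ring carbon gives a number 8 percentage points lower from compound 2 to compound 4 (within the scatter), so on this core the swap alone does not clear the scatter. Read with thiophen-2-yl as the incoming group, the swap points the same way on both ester cores, and the two steps agree: the same change on two cores in this assay, a number 11 percentage points higher (beyond the scatter) from compound 1 to compound 3 and a number 8 percentage points higher (within the scatter) from compound 4 to compound 2, 3 percentage points apart, within the scatter of two such steps With phenyl held fixed, the change from the isopropyl ester to the ethyl ester gives a number 2 percentage points lower from compound 1 to compound 4 (within the scatter), and this ester change also agrees across the two aryl groups: the same change on two cores in this assay, a number 5 percentage points higher (within the scatter) from compound 2 to compound 3 and a number 2 percentage points higher (within the scatter) from compound 4 to compound 1, 3 percentage points apart, within the scatter of two such steps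

All four readings in this assay come from a single concentration, so they give no potency. As far as these compounds go, what a pyridin-3-yl or cyclohexyl group would give on that saturated ring carbon stays open, as does the effect of a longer ester chain.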